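This account rests on a few compounds, and the source may have more. Where it says the series, first, only, none or still open, it means among the compounds named here.

Values measured so far in a physicochemical assay for lipophilicity; a lower number here means a more polar compound, a higher number a more lipophilic compound

- compound 1 `CC(C)c1cc(Br)cc(C(C)C)c1O` gives 5.49
- compound 2 `COS(=O)(=O)c1cc(C(C)C)c(O)c(C(C)C)c1` gives 3.7
- compound 3 `CC(C)c1cc(C(=O)c2ccccc2)cc(C(C)C)c1O` gives 5.91

Compound 2 has the lowest number of the three in this assay and the other two lie above it, beyond the scatter. Compound 4 `CC(C)c1cc(N)cc(C(C)C)c1O` keeps the shared core and changes one group. The change is amino in place of methoxysulfonyl on an aromatic carbon and it puts amino in place of methoxysulfonyl on an aromatic carbon.

Among the compounds with values here, only one measured step bears on this place, and it is large: a number 1.79 log units lower from compound 1 to compound 2 (beyond the scatter) in all. That step shows that exchanging this group can move the number a long way. Within the data shown here, it does not involve amino, however, and no measured compound carries that group, so it is only a loose guide. The expected step is a number 0.50 log units lower from compound 2 to compound 4 (beyond the scatter) and it is a moderate move downward, with a wide margin on either side. For compound 4 the estimated value is 3.2 on this scale, with an expected range from 2.5 to 3.9 around it.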

Compound 4, partition coefficient: 3.1
For compound 4 the middle estimate is 0.10 log units above the measured one, within the range that was stated.
By their numbers in this assay, from the lowest: compound 4; then compound 2; then compound 1; then compound 3.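

In this assay methoxysulfonyl did not mark the bottom of the range at this aromatic carbon, since amino gives a number 0.60 log units lower from compound 2 to compound 4 (beyond the scatter) and, measured against bromo, a number 2.39 log units lower from compound 1 to compound 4 (beyond the scatter) and so leaves compound 4 with the lowest number of the set. The number therefore does not simply fall as the group grows here: amino has 1 heavy atom and 1 hydrogen-bond donor, while methoxysulfonyl has 5 heavy atoms and no hydrogen-bond donor, yet amino gives the lower number. No measurement shown explains why this exchange moves the number as it does.

From the compounds shown here alone, whether an acetamide or a carboxylic acid on this carbon would fall above or below amino remains open. So does whether a methylamino group would stay close to amino or move away from it.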